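From 2-nitrophenyl to 3,4-dimethoxyphenyl on a shared core

The source may hold more compounds than are shown below. What is called first, only, known or untested is meant among the compounds shown, and "the series" means these compounds.

- compound 1 `C[C@H]1CC[C@@H]2[C@@H](OC(=O)[C@]23CC(c2ccccc2)=NO3)[C@]2(C)C(=O)C=C[C@@]12O`: 39800 nM
- compound 2 `C[C@H]1CC[C@@H]2[C@@H](OC(=O)[C@]23CC(c2ccccc2[N+](=O)[O-])=NO3)[C@]2(C)C(=O)C=C[C@@]12O`: 34000 nM

Both values come from a functional assay on DU-145 cells (Homo sapiens) for cytotoxicity, read by sulforhodamine B assay, with a stated time of 48 h; a lower number here means a stronger inhibitor, a higher number a weaker inhibitor. Compound 2 stands within the scatter of compound 1, so the two cannot be ranked. Compound 3 `COc1ccc(C2=NO[C@]3(C2)C(=O)O[C@@H]2[C@H]3CC[C@H](C)[C@]3(O)C=CC(=O)[C@@]23C)cc1OC` has not yet been measured. It differs from compound 2 by 3,4-dimethoxyphenyl in place of 2-nitrophenyl on a carbon with a double bond to nitrogen. Among the compounds with values here, only one measured step bears on this change: a 1.2-fold lower number from compound 1 to compound 2 (0.07 log units; within the scatter), with nitro in place of hydrogen on an aromatic carbon. Within the data shown here, no measured compound carries a methoxy group, so the evidence is thin. No step beyond the scatter is therefore expected in this assay. The estimated step is a 1.0-fold higher number from compound 2 to compound 3 (0.01 log units; within the scatter). The estimate for compound 3 is 35000 nM, expected to fall between 15000 nM and 80000 nM.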

Compound 3, half-maximal inhibitory concentration: 84000 nM
Estimate against measurement, compound 3: 2.4-fold (0.38 log units) below; the measured number lies above the stated range.
By their numbers in this assay, from the lowest: compounds 2 and 1 (each within the scatter of the next); then compound 3.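

In this assay, the carbon with a double bond to nitrogen turns out to be a place where a change of aryl group can move the number beyond the scatter, which adding the nitro group had not done. With 3,4-dimethoxyphenyl there is a 2.5-fold higher number from compound 2 to compound 3 (0.39 log units; beyond the scatter) and also a 2.1-fold higher number from compound 1 to compound 3 (0.32 log units; beyond the scatter) so, modest as they are, both steps leave compound 3 as the weakest of the three, while compound 1 and compound 2 remain unranked. No measurement at hand says what lies behind this shift.

The compounds shown leave open whether a single methoxy group on the phenyl ring would give the same step as the pair. They also leave open whether an aminophenyl group, a carboxyphenyl group or a plain alkyl chain at this carbon would stay with compound 1 and compound 2 or move with compound 3.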